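The compounds below may be only part of what the source reports. "The series", "measured", "known", "first", "only" and "open" are said of these compounds alone.

Working notes on the series. For the measured compounds named here, in an ADME assay on WI-38 cells (Homo sapiens) for cytotoxicity, read by MTT assay, with a stated time of 48 h (a higher number here means a weaker inhibitor, a lower number a stronger inhibitor), compound 1 `CNC(=O)c1cc(-n2ccc3cc(NC(=O)Nc4ccc(Cl)c(Cl)c4)ccc32)ccn1` gives 23100 nM and is the only member of the series with a number rather than a limit. Compound 2 `CNC(=O)c1cc(-n2ccc3cc(NC(=O)Nc4cc(C(F)(F)F)cc(C(F)(F)F)c4)ccc32)ccn1` gives > 30000 nM in this assay, which is a limit of the assay and not a number. Compound 3 `CNC(=O)c1cc(-n2ccc3cc(NC(=O)Nc4ccc(N5CCN(C)CC5)c(C(F)(F)F)c4)ccc32)ccn1` gives > 30000 nM in this assay, again a limit and not a number. The picture is set by the limit of > 30000 nM in this assay, at which 2 of the 3 values shown sit, and compound 1 stands close to it. Going by the values given here, no step between measured compounds differing in one place is available, so no measured step size can be quoted.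

Compound 4 `CNC(=O)c1cc(-n2ccc3cc(NC(=O)c4cccc(C(F)(F)F)c4)ccc32)ccn1` is not yet measured. It differs from compound 1 by 3-(trifluoromethyl)phenyl in place of (3,4-dichlorophenyl)amino on a carbonyl carbon. Compound 1 gives 23100 nM. The values of compound 2 and compound 3 are both limits of the assay and not numbers. The expected step of a 1.2-fold higher number from compound 1 to compound 4 (0.08 log units; within the scatter) is therefore small, within the scatter, and if anything toward the limit. The estimate for compound 4 is 28000 nM, with a range from 14000 nM to 60000 nM, and a real chance that only a limit is reported.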

Compound 4, half-maximal inhibitory concentration: 6500 nM
For compound 4 the middle estimate is 4.3-fold (0.63 log units) above the measured one, outside the stated range (below it).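

For the compounds shown here, replacing (3,4-dichlorophenyl)amino with 3-(trifluoromethyl)phenyl on a carbonyl carbon gives, in this assay, a 3.6-fold lower number from compound 1 to compound 4 (0.55 log units; beyond the scatter), the first step that can be read as a number. The group on this carbonyl carbon can therefore move the read-out beyond the scatter, in a series otherwise bounded by a limit of the assay: the limit of > 30000 nM in this assay, at which 2 of the 4 values shown sit. The change swaps the amino link and the ring substituents together, so the step belongs to the whole group and not to either part.

Steps involving compound 2 and compound 3 cannot be read. Still open, on these data alone, is whether 3,4-dichlorophenyl directly on the carbonyl carbon, or (3-(trifluoromethyl)phenyl)amino in the same place, would follow compound 4 or compound 1.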